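The compounds below may be only part of what the source reports. "The series", "measured", "known", "first", "only" and "open" are said of these compounds alone.

In a functional assay on 786-0 cells (Homo sapiens) for inhibition, read by sulforhodamine B assay, with a stated time of 48 h (on this read-out lower numbers stand for stronger inhibition of growth and higher numbers for weaker inhibition of growth), compound 1 `CC1=CC[C@H](C(C)(C)NC(=S)NN)CC1` gives > 100000 nM, a limit of the assay and not a number. Compound 2 `CC1=CC[C@H](C(C)(C)NC(=S)N/N=C/c2ccc(O)cc2)CC1` also reaches only a limit in this assay, at > 100000 nM. Among the measured compounds shown here, compound 3 `CC1=CC[C@H](C(C)(C)NC(=S)N/N=C/c2ccc(N(C)C)cc2)CC1` is the one member of the series with a numerical value in this assay, 87000 nM. For the measured compounds named here, the only step measured between neighbours, an at least 1.1-fold lower number from compound 2 to compound 3 (0.06 log units; that floor lies within the scatter), is therefore bounded by a floor and tells little about the effect of changing the aromatic substituent. Compound 2 thus stands where most of the series stands, at the limit of > 100000 nM in this assay, at which 2 of the 3 values shown sit, and no number separates it from compound 1.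

Compound 4 `CC1=CC[C@H](C(C)(C)NC(=S)N/N=C/c2ccccc2Cl)CC1` differs from compound 2 in one place: 2-chlorophenyl in place of 4-hydroxyphenyl on a carbon with a double bond to nitrogen. Going by the values given here, no measured step involves the 2-chlorophenyl group, so the expectation rests on the one step from compound 2 to compound 3 and on the two limits. A change of the same kind, the exchange of one aromatic group for another, gave at most a shift within the scatter, so for compound 4 the step of an at least 1.1-fold lower number from compound 2 to compound 4 (0.04 log units; that floor lies within the scatter) is expected to be small, with a real chance that only a limit is reported again. Compound 4 is estimated at 90000 nM, between 30000 nM and 250000 nM.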

Compound 4, concentration for 50% growth inhibition: 85500 nM
For compound 4 the middle estimate is 1.1-fold (0.02 log units) above the measured one, and the stated range covers the measured number.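

The new result shows that a second exchange at this place, on a carbon with a double bond to nitrogen, also gives a number rather than a limit in this assay, with an at least 1.1-fold lower number from compound 2 to compound 4 (0.06 log units; that floor lies within the scatter). With the 2-chlorophenyl group, which counts no hydrogen-bond donor and no hydrogen-bond acceptor where 4-hydroxyphenyl counts one of each, compound 4 gives 85500 nM, while compound 3 gives 87000 nM, so two different aromatic groups at this place leave values that cannot be told apart. Compound 2 itself remains a limit of the assay and not a number: the limit of > 100000 nM in this assay, at which 2 of the 4 values shown sit.

The compounds shown leave open how far the step from compound 2 really reaches, since only a floor is known for it and that floor does not rise beyond the scatter. They also leave open whether a carboxylic acid or an amine on the aromatic ring, or a longer chain in place of the aromatic group, would move growth inhibition in this series any further than the groups seen so far.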